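The source may report more compounds than this note shows. Statements on the series, on what has been measured and on what is new or still open speak of the compounds shown alone.

Measured so far in a functional assay on B16 cells (Mus musculus) for cytotoxicity, read by MTT assay, with a stated time of 72 h; a lower number here means a stronger inhibitor, a higher number a weaker inhibitor:
- compound 1 `COc1ccc(C(=O)c2cc(OC)c(OC)c(OC)c2)cc1NC(=O)/C=C/c1ccc(C(F)(F)F)cc1` gives 100 nM
- compound 2 `COc1cc(/C=C/C(=O)Nc2cc(C(=O)c3cc(OC)c(OC)c(OC)c3)ccc2OC)ccc1F` gives 16300 nM
- compound 3 `COc1ccc(C(=O)c2cc(OC)c(OC)c(OC)c2)cc1NC(=O)/C=C/c1cccc(OC(F)(F)F)c1` gives 6300 nM

Compound 3 stands second highest of the three numbers: compound 3 sits nearest to compound 2, as shown by a 2.6-fold lower number from compound 2 to compound 3 (0.41 log units; beyond the scatter), and far from compound 1, as shown by a 63-fold higher number from compound 1 to compound 3 (1.80 log units; beyond the scatter). Compound 4 `COc1ccc(C(=O)c2cc(OC)c(OC)c(OC)c2)cc1NC(=O)/C=C/c1ccc([N+](=O)[O-])cc1` differs from compound 3 by 4-nitrophenyl in place of 3-(trifluoromethoxy)phenyl on a double-bonded chain carbon bound to a double-bonded chain carbon. Among the compounds with values here, two measured steps bear on this: the large step of a 63-fold higher number from compound 1 to compound 3 (1.80 log units; beyond the scatter) and the modest step of a 2.6-fold lower number from compound 2 to compound 3 (0.41 log units; beyond the scatter), both swapping the aryl group at the same place. Compound 4 carries a 4-nitrophenyl, like compound 1 carrying a 4-(trifluoromethyl)phenyl, so a large step to a lower number is expected, a 16-fold lower number from compound 3 to compound 4 (1.20 log units; beyond the scatter). Compound 4 is estimated at 400 nM, between 60 nM and 3000 nM.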

Compound 4, half-maximal inhibitory concentration: 6400 nM
Compound 4: the middle estimate sits 16-fold (1.20 log units) below what was measured, outside the stated range (above it).
By their numbers in this assay, from the lowest: compound 1; then compounds 3 and 4 (each within the scatter of the next); then compound 2.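

In this assay, nitro in place of trifluoromethyl on an aromatic carbon is a large change, a 64-fold higher number from compound 1 to compound 4 (1.81 log units; beyond the scatter), so 4-nitrophenyl does not share the low number of 4-(trifluoromethyl)phenyl. Swapping 3-(trifluoromethoxy)phenyl for 4-nitrophenyl stays within the scatter, a 1.0-fold higher number from compound 3 to compound 4 (0.01 log units; within the scatter), while swapping 4-fluoro-3-methoxyphenyl for it gives a 2.5-fold lower number from compound 2 to compound 4 (0.41 log units; beyond the scatter). Within the data shown here, of the four aryl groups at this place, only the one in compound 1 gives a low number, and no measurement here explains this. On these data alone, whether a nitrile, a chlorine or an amine in place of trifluoromethyl on an aromatic carbon would come close to compound 1 stays open.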